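This account rests on a few compounds, and the source may have more. Where it says the series, first, only, none or still open, it means among the compounds named here.

Measured so far:
compound 1, `CN(C)CCC(NC(=O)/C=C/c1ccc(C(F)(F)F)cc1)c1ccc2ccccc2c1`: 135 nM
compound 2, `Cc1ccc(C(CCN(C)C)NC(=O)CCc2ccccc2)cc1`: 4570 nM
compound 3, `CN(C)CCC(NC(=O)/C=C/c1ccccc1)c1ccc2ccccc2c1`: 589 nM

All three were tested in a functional assay on NIH3T3 cells for agonist activity at Urotensin-2 receptor (Homo sapiens), with a stated time of 5 days; on this read-out lower numbers stand for an effect already at smaller amounts and higher numbers for an effect only at larger amounts of compound. Compound 3 and compound 1 differ only by trifluoromethyl in place of hydrogen on an aromatic carbon, and this step gave a 4.4-fold lower number from compound 3 to compound 1 (0.64 log units; beyond the scatter). Compound 2 has the highest number of the three; the difference between its core and the core of compound 3 is not broken down here. Compound 4, `Cc1ccc(C(CCN(C)C)NC(=O)CCc2ccc(C(F)(F)F)cc2)cc1`, has not yet been measured; it differs from compound 2 by trifluoromethyl in place of hydrogen on an aromatic carbon, the same change seen once before. Because the earlier step gave a 4.4-fold lower number from compound 3 to compound 1 (0.64 log units; beyond the scatter) on a different core, a step of similar kind is expected here, though perhaps smaller, so compound 4 is estimated at a 3.0-fold lower number from compound 2 to compound 4 (0.48 log units; beyond the scatter) in this assay. The expected value for compound 4 is therefore 1500 nM, with a likely range from 500 nM to 4500 nM.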

Compound 4, half-maximal effective concentration: 2290 nM
The estimate for compound 4 lay 1.5-fold (0.18 log units) below the measured number, within the range that was stated.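

In this assay, putting trifluoromethyl in place of hydrogen gave a 2.0-fold lower number from compound 2 to compound 4 (0.30 log units; within the scatter), so on this core the step alone cannot be told apart from the ordinary spread of repeated measurements. Set beside the earlier step, it shows no measurable difference between the two cores: the same change on two cores in this assay, a 4.4-fold lower number (0.64 log units; beyond the scatter) from compound 3 to compound 1 and a 2.0-fold lower number (0.30 log units; within the scatter) from compound 2 to compound 4, 2.2-fold (0.34 log units) apart, within the scatter of two such steps. This is compatible with the change carrying over from one core to the other, but it does not establish that: two cores are few, and the step on the core of compound 2 is not a clear effect by itself.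

Going by these compounds, whether a nitrile or a single fluorine atom in that place would give a similar step remains open. The same holds for an amine or a carboxylic acid there.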